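Swapping an Allyl(methyl)amino Group for Cyclopropylamino

A few compounds are considered here, and "the series" means these few. Any claim that something is new, unique, unknown or untested is made for them only; others in the source may bear on it.

Three related nucleoside analogues have been tested in an ADME assay on CCRF-CEM cells (Homo sapiens) for cytotoxicity, with a stated time of 5 days; on this read-out higher numbers stand for weaker inhibition and lower numbers for stronger inhibition. Compound 1, `C=CCN(C)c1nc(N)nc2c1ncn2[C@H]1C[C@H](N=[N+]=[N-])[C@@H](CO)O1`, gives 27000 nM. Compound 2, `[N-]=[N+]=N[C@H]1C[C@H](n2cnc3c(N)nc(F)nc32)O[C@@H]1CO`, gives 30100 nM in this assay, a value within the usual scatter of compound 1, so the two cannot be separated. Compound 3, `COc1nc(F)nc2c1ncn2[C@H]1C[C@H](N=[N+]=[N-])[C@@H](CO)O1`, reaches only the assay limit of > 100000 nM in this assay. Among the numbers shown, compound 1 therefore sits together with compound 2 at the low end, with the third value being a limit rather than a number.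

Among the measured compounds shown here, the one measured step, an at least 3.3-fold higher number from compound 2 to compound 3 (0.52 log units; beyond the scatter), concerns a different part of the shared core than the change considered here, and the only evidence touching it is the limit of > 100000 nM in this assay, at which 1 of the 3 values shown sits.

Compound 4, `[N-]=[N+]=N[C@H]1C[C@H](n2cnc3c(NC4CC4)nc(N)nc32)O[C@@H]1CO`, has not been measured. It differs from compound 1 by cyclopropylamino in place of allyl(methyl)amino on an aromatic carbon. For the measured compounds named here, no measured step involves this position or either of these groups, so nothing in the data argues for a shift beyond the scatter in this assay in either direction. The expected value for compound 4 is therefore estimated at 30000 nM, within a range of 10000 nM to 90000 nM, which corresponds to an expected step of a 1.1-fold higher number from compound 1 to compound 4 (0.05 log units; within the scatter).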

Compound 4, half-maximal inhibitory concentration: > 100000 nM
Compound 4: a limit, no number (the forecaster's own chance of this, stated with the estimate: 15%); at least 3.3-fold (0.52 log units) between middle value and limit.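

In this assay, among the compounds shown here, the position carrying the allyl(methyl)amino group, which no earlier step touched, turns out to matter: cyclopropylamino in its place gives an at least 3.7-fold higher number from compound 1 to compound 4 (0.56 log units; beyond the scatter). The value for compound 4 is a limit of the assay and not a number, so this step gives only a lower bound on the size of the change, not its true size, and the weakening of inhibition could be larger: the limit of > 100000 nM in this assay, at which 2 of the 4 values shown sit. The swap also changes more than one feature at once, since the entering cyclopropylamino brings a three-membered ring and a hydrogen-bond donor, while the departing allyl(methyl)amino has no ring, no hydrogen-bond donor and a double bond outside aromatic rings.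

The compounds shown therefore leave open which of these differences goes with the higher number. A cyclopropyl(methyl)amino group at this position, which keeps the ring without the hydrogen-bond donor, and a plain methylamino group, which has the donor without the ring, would help to pull those features apart.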